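Dropping the Ethoxycarbonyl Group: Expected Cytotoxicity of Compound 4

This account rests on a few compounds, and the source may have more. Where it says the series, first, only, none or still open, it means among the compounds named here.

Compound 1 `CCOC(=O)c1ccc(NC(=O)CSc2snnc2-c2ccccc2)c(Br)c1` was examined in an ADME assay on MT4 cells (Homo sapiens) for cytotoxicity; on this read-out lower numbers stand for higher toxicity in this test and higher numbers for lower toxicity in this test. In this assay compound 1 gives >= 232000 nM, which is a limit of the assay rather than a number (the limit of >= 232000 nM in this assay, at which 1 of the 3 values shown sits). Compound 2 `CCOC(=O)c1ccc(NC(=O)CSc2snnc2-c2ccc(Cl)cc2Cl)c(Br)c1` gives > 228000 nM, likewise a limit (the limit of > 228000 nM in this assay, at which 1 of the 3 values shown sits). Compound 3 `COc1ccc(-c2nnsc2SCC(=O)Nc2ccccc2Cl)cc1` gives > 318000 nM, again a limit (the limit of > 318000 nM in this assay, at which 1 of the 3 values shown sits). Within the data shown here, the only measured step that touches compound 1 is a step that the two limits leave unreadable from compound 1 to compound 2, whose size the two limits leave unreadable. Compound 4 `O=C(CSc1snnc1-c1ccccc1)Nc1ccccc1Br` differs from compound 1 by hydrogen in place of ethoxycarbonyl on an aromatic carbon. With every value shown sitting at a limit, no step beyond the scatter can be read, and compound 4 is therefore expected to remain at the limit as well. The expected step is a step that the limit leaves unreadable from compound 1 to compound 4. For compound 4 the estimate is 250000 nM, with a range from 120000 nM to 500000 nM.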

Compound 4, half-maximal cytotoxic concentration: > 307000 nM
Compound 4 gave a limit, no number; the forecaster's own chance of this, stated with the estimate: 85%; at least 1.2-fold (0.08 log units) between middle value and limit.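

Compound 1 and compound 4 both stand at limits, so no step can be read between them. The compounds shown leave open what values in this assay lie behind the limits of all four compounds.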